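Methylamino for methyl at the ring carbon in the shared core

The compounds below may be only part of what the source reports. "The series", "measured", "known", "first", "only" and "open" are said of these compounds alone.

Within the data shown here, compound 2 `Cc1nc(NCc2ccc(Cl)cc2)cc(-c2ccccn2)n1` gives 17 nM in a functional assay on HEK293 cells for agonist activity at G-protein coupled receptor 39 (Mus musculus), read by inositol phosphate accumulation (a lower number here means that less compound is needed, a higher number that more compound is needed for the effect), the second highest of the three numbers known. Compound 3 `CNc1nc(NCc2ccc(Cl)cc2Cl)cc(-c2ccccn2)n1` gives 0.5 nM in this assay, and compound 1 `CNc1nc(NCc2ccc(N(C)C(C)=O)cc2)cc(-c2ccccn2)n1` gives 2610 nM; both carry a methylamino group on the core where compound 2 carries methyl, while their other parts also differ from compound 2. Compound 4 `CNc1nc(NCc2ccc(Cl)cc2)cc(-c2ccccn2)n1` is not yet measured. It differs from compound 2 in one place: methylamino in place of methyl on an aromatic carbon.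

Among the measured compounds shown here, no single-change step is available to calibrate this exchange. Given that compound 3 with methylamino reaches 0.5 nM, a step toward a lower number is expected, of moderate size, estimated as a 3.4-fold lower number from compound 2 to compound 4 (0.53 log units; beyond the scatter). Compound 4 is thus expected to give about 5 nM, within 1 nM to 30 nM.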

Compound 4, half-maximal effective concentration: 3 nM
Beside the measured number, compound 4's estimate is 1.7-fold (0.22 log units) above it; measured number inside the range.
By their numbers in this assay, from the lowest: compound 3; then compound 4; then compound 2; then compound 1.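

Taken alone in this assay, methylamino in place of methyl on the aromatic carbon between two ring nitrogen atoms gives a step beyond the scatter (a 5.7-fold lower number from compound 2 to compound 4 (0.75 log units; beyond the scatter)). With methylamino held constant, hydrogen in place of chloro gives a step of similar size in the opposite direction (a 6.0-fold higher number from compound 3 to compound 4 (0.78 log units; beyond the scatter)). Chloro in place of acetyl(methyl)amino gives a far larger step (an 870-fold lower number from compound 1 to compound 4 (2.94 log units; beyond the scatter)), so that place on the compounds outweighs the core exchange.

From the compounds shown here alone, whether an ethylamino group or an unsubstituted amine at this carbon would continue the step remains open. No measurement here explains any of these steps.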